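Moving the chlorine from compound 3 to compound 4

The source may report more compounds than this note shows. Statements on the series, on what has been measured and on what is new or still open speak of the compounds shown alone.

- compound 1 `O=C(CCl)Nc1ccc(C(=O)/C=C/c2ccccc2)cc1`: 6370 nM
- compound 2 `O=C(CCl)Nc1ccc(C(=O)/C=C/c2ccc(Br)cc2)cc1`: 10100 nM
- compound 3 `O=C(CCl)Nc1ccc(C(=O)/C=C/c2ccccc2Cl)cc1`: 6980 nM

In a functional assay on EC9706 cells (Homo sapiens) for cytotoxicity, read by MTT assay, with a stated time of 72 h (on this read-out higher numbers stand for weaker inhibition and lower numbers for stronger inhibition), compound 3 cannot be told apart from the other two: a 1.1-fold higher number from compound 1 to compound 3 (0.04 log units; within the scatter), and a 1.4-fold lower number from compound 2 to compound 3 (0.16 log units; within the scatter). Compound 4 `O=C(CCl)Nc1ccc(C(=O)/C=C/c2cccc(Cl)c2)cc1` has 3-chlorophenyl in place of 2-chlorophenyl on a double-bonded chain carbon bound to a double-bonded chain carbon. Going by the values given here, no measured step tests this move directly. The closest evidence is that chloro in place of hydrogen gave a 1.1-fold higher number from compound 1 to compound 3 (0.04 log units; within the scatter), while bromo gave a 1.6-fold higher number from compound 1 to compound 2 (0.20 log units; within the scatter). No step beyond the scatter is therefore expected in this assay. The expected change is a 1.0-fold higher number from compound 3 to compound 4 (0.00 log units; within the scatter). For compound 4 the estimated value is 7000 nM, with an expected range from 3500 nM to 14000 nM.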

Compound 4, half-maximal inhibitory concentration: 5560 nM
For compound 4 the middle estimate is 1.3-fold (0.10 log units) above the measured one; low and high end bracket the measured number.
By their numbers in this assay, from the lowest: compounds 4, 1, 3 and 2 (each within the scatter of the next).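

In this assay, going by these compounds alone, 3-chlorophenyl in place of 2-chlorophenyl is the first direct test of where the chlorine sits on this ring, and it stays within the scatter (a 1.3-fold lower number from compound 3 to compound 4 (0.10 log units; within the scatter)). Chloro in place of hydrogen at this new place also stays within the scatter (a 1.1-fold lower number from compound 1 to compound 4 (0.06 log units; within the scatter)), as does the change from 4-bromophenyl (a 1.8-fold lower number from compound 2 to compound 4 (0.26 log units; within the scatter)). No measurement shown here explains these results.

The compounds shown carry only hydrogen or a halogen on this ring, so the effect of an amine or a carboxylic acid there remains open.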